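Cyclohexyl to Benzyl on an Aromatic Nitrogen

The compounds below may be only part of what the source reports. "The series", "measured", "known", "first", "only" and "open" are said of these compounds alone.

The measure here is an assay on HEK293 cells for activation of Kir3.1/Kir3.2 (Homo sapiens), read by thallium flux; on this read-out lower numbers stand for smaller maximal responses and higher numbers for larger maximal responses. Among the measured compounds shown here, compound 1 `Cc1cc(NC(=O)Cn2nnc(-c3ccccc3)n2)n(C2CCCCC2)n1` is the only compound with a reported number: in this assay compound 1 gives 92%, a response close to the reference. Compound 2 `Cc1nc(NC(=O)Cn2nnc(-c3ccccc3)n2)n(-c2ccccc2)n1` differs from compound 1 in more than one place, so the two cannot be compared as a single step; in this assay compound 2 gives "not active" (no number reported), and no more follows from it. Compound 3 `Cc1cc(NC(=O)Cn2nnc(-c3ccccc3)n2)n(Cc2ccccc2)n1` has not yet been measured. It keeps the core of compound 1 and changes one thing: benzyl in place of cyclohexyl on an aromatic nitrogen. For the measured compounds named here, no measured pair isolates this kind of change, so there is no step to lean on. The expectation is a moderate loss in maximal response, a number 17 percentage points lower from compound 1 to compound 3 (beyond the scatter), though a result within the usual scatter of this assay would not be surprising. The missing number for compound 2 also leaves some chance that compound 3 is reported without one. Compound 3 is estimated at 75% in this assay, with an expected range from 40% to 100%.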

Compound 3, largest response reached (Emax), in percent of the reference or control that the assay uses: 74%
Compound 3: the middle estimate sits 1 percentage points above what was measured, within the range that was stated.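

Among the compounds shown here, replacing cyclohexyl with benzyl on the aromatic nitrogen gives the first measured step at this position in this assay, with a number 18 percentage points lower from compound 1 to compound 3 (beyond the scatter) as its size. The step shows that the position can hold a six-membered aromatic ring of carbon as well as a non-aromatic one: the maximal response falls, yet compound 3 still reaches 74% and is far from inactive. The data include no measurement that explains the fall, and this single step cannot separate the change from a non-aromatic to an aromatic ring from the difference between the 6 heavy atoms of cyclohexyl and the 7 of benzyl.

From the compounds shown here alone, it remains open whether a smaller group such as isopropyl, a longer chain such as phenethyl, or a cyclohexyl ring carrying an amine would keep, lower or raise the response at this position. It is also unknown whether benzyl would bring a similar change on a different core, and compound 2 offers no guide, as it has no reported number and differs from compound 1 in more than one place.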